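The compounds below may be only part of what the source reports. "The series", "measured", "known", "first", "only" and "open" are said of these compounds alone.

Measured compounds:
compound 1, `C#CCCCCCCCCCOC(=O)c1ccn(-c2cccc(OC(=O)NCCCC)c2)c1`: > 70 nM
compound 2, `C#CCCCCCCCCCOC(=O)c1ccn(-c2cccc(OC(=O)NC3CCCCC3)c2)c1`: > 10000 nM
compound 3, `CCCCNC(=O)Oc1cccc(-c2oc(C)cc2C(N)=O)c1`: 530 nM

All three were tested in an assay (brain) for inhibition of Fatty-acid amide hydrolase 1 (Mus musculus), with stated times of 20 min and 15 min; on this read-out lower numbers stand for stronger inhibition and higher numbers for weaker inhibition. Among the compounds with values here, compound 3 is the only one with a definite number there, 530 nM. For compound 1 the result is a limit of the assay, > 70 nM. For compound 2 the result is also a limit, > 10000 nM. The change from compound 1 to compound 2 is cyclohexyl in place of butyl on an amide-type nitrogen, and its size is a step that the two limits leave unreadable from compound 1 to compound 2 because the limit of > 70 nM in this assay, at which 1 of the 3 values shown sits, and the limit of > 10000 nM in this assay, at which 1 of the 3 values shown sits, bound both values. The difference between the core of compound 1 and the core of compound 3 is not broken down here.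

Compound 4, `Cc1cc(C(N)=O)c(-c2cccc(OC(=O)NC3CCCCC3)c2)o1`, has not yet been measured. It differs from compound 3 by cyclohexyl in place of butyl on an amide-type nitrogen, the same change that turns compound 1 into compound 2. Since that earlier step cannot be read, the expectation for compound 4 rests on compound 3 at 530 nM and on compound 2 sitting at the limit of > 10000 nM in this assay, at which 1 of the 3 values shown sits. Compound 4 is therefore expected to come out weaker, around 3000 nM, spanning 800 nM to 15000 nM, a step of a 5.7-fold higher number from compound 3 to compound 4 (0.75 log units; beyond the scatter).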

Compound 4, half-maximal inhibitory concentration: > 70 nM
Compound 4: only a limit was reported; the forecaster's own chance of this, stated with the estimate: 35%; the middle value does not contradict the limit.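

In this assay compound 4 gives > 70 nM and this is a limit of the assay, not a number. No size can therefore be read for the change from compound 3 to compound 4. The compounds shown leave open how far cyclohexyl in place of butyl on an amide-type nitrogen shifts inhibition on either core.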